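Carbamate variation on a bis(trimethoxybenzoyl)piperazine scaffold

The source may report more compounds than this note shows. Statements on the series, on what has been measured and on what is new or still open speak of the compounds shown alone.

Compound 1 `CCCCCCCC(=O)OCC1CN(C(=O)c2cc(OC)c(OC)c(OC)c2)CCN1C(=O)c1cc(OC)c(OC)c(OC)c1` gives 310 nM in a functional assay (Oryctolagus cuniculus) for inhibition of platelet-activating factor receptor (Cavia porcellus); a higher number here means a weaker inhibitor, a lower number a stronger inhibitor.
Compound 2 `COc1cc(C(=O)N2CCN(C(=O)c3cc(OC)c(OC)c(OC)c3)C(COC(=O)C(C)(C)C)C2)cc(OC)c1OC` gives 100 nM; 100 nM; 120 nM (3 entries) in this assay.
Compound 3 `COc1cc(C(=O)N2CCN(C(=O)c3cc(OC)c(OC)c(OC)c3)C(COC(=O)NC(C)(C)C)C2)cc(OC)c1OC` gives 130 nM in this assay.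

Compound 3 holds the lower of the two single numbers in this assay; its nearest neighbour is compound 1, separated by a 2.4-fold lower number from compound 1 to compound 3 (0.38 log units; beyond the scatter), while the repeated entries of compound 2 the several entries of compound 2 in this assay, 100 nM; 100 nM; 120 nM (3 entries) lie in the same region as compound 3 and cannot be ordered against it.

Compound 4 `COc1cc(C(=O)N2CCN(C(=O)c3cc(OC)c(OC)c(OC)c3)C(COC(=O)NC(C)C(C)C)C2)cc(OC)c1OC` differs from compound 3 only by 1,2-dimethylpropyl in place of tert-butyl on an amide-type nitrogen. Among the measured compounds shown here, no measured step touches this part of the molecule; the single measured step concerns an exchange on the carbonyl carbon and is modest. A change of this kind is therefore expected to give no change at the digits printed from compound 3 to compound 4 (within the scatter), no shift beyond the scatter in this assay. Compound 4 is estimated at 130 nM, within a range from 60 nM to 300 nM.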

Compound 4, half-maximal inhibitory concentration: 80 nM
Beside the measured number, compound 4's estimate is 1.6-fold (0.21 log units) above it; low and high end bracket the measured number.
By their numbers in this assay, from the lowest: compounds 4 and 3 (each within the scatter of the next); then compound 1.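

Swapping tert-butyl for 1,2-dimethylpropyl on the amide-type nitrogen gives a 1.6-fold lower number from compound 3 to compound 4 (0.21 log units; within the scatter) in this assay, so these two branched groups cannot be told apart at this position. Replacing heptyl on the carbonyl carbon with (1,2-dimethylpropyl)amino gives a 3.9-fold lower number from compound 1 to compound 4 (0.59 log units; beyond the scatter), which shows that the step away from heptyl is not confined to (tert-butyl)amino. Nothing in the data gives a reason for either result. As far as these compounds go, it remains open whether a straight butyl chain, a cyclohexyl ring or a phenyl ring on this nitrogen would fall in the same range.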